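This account rests on a few compounds, and the source may have more. Where it says the series, first, only, none or still open, it means among the compounds named here.

In an ADME assay on microsomes from liver (Homo sapiens) for metabolic stability, read by LC-MS, with NADPH named in the record, with a stated time of 60 min, tested at 1 uM, in the absence of a further agent (on this read-out higher numbers stand for a more stable compound and lower numbers for a less stable compound), two compounds with the same core have been measured so far: compound 1 `COc1ccc(-c2c(C)nc3c(N4CC=CC4)cc(C)nn23)cc1OC` and compound 2 `COc1ccc(-c2c(C)nc3c(N4CCN(C(=O)C5CCCCC5)CC4)cc(C)nn23)cc1OC`. Compound 1 gives > 95%, which is a limit of the assay and not an exact number. Compound 2 gives > 95%, which is also a limit. From the compounds shown here alone, the whole record in this assay is therefore (the limit of > 95% in this assay, at which 2 of the 2 values shown sit), and the exact standing of compound 2 remains unknown. Among the measured compounds shown here, the two measured compounds offer no step from a single change to learn from.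

Compound 3 `COc1ccc(-c2c(C)nc3c(N4CCN(C(C)=O)CC4)cc(C)nn23)cc1OC` keeps all of compound 2 except one group, with methyl in place of cyclohexyl on a carbonyl carbon. Cut one bond further out, this reads cyclohexylcarbonyl to acetyl. The expectation rests on compound 2, which carries the cyclohexyl and gives > 95% as a limit. In this assay, the expected change a number at least 1 percentage points lower from compound 2 to compound 3 (that floor lies within the scatter) is none beyond the usual scatter of repeated measurements. For compound 3 the estimated value is 94%, with an expected range from 82% to 100%.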

Compound 3, percent of the compound remaining: > 95%
Compound 3 ended at the assay's limit; the forecaster's own chance of this, stated with the estimate: 55%; middle value at least 1 percentage points from the limit.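

Compound 3 sits at the same limit as compound 1 and compound 2, so no size can be read for its steps from either compound in this assay: the limit of > 95% in this assay, at which 3 of the 3 values shown sit.

The compounds shown leave open how much of each compound truly remains in this assay and whether any change on the shared core would give a readable difference.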